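The source may hold more compounds than are shown below. What is called first, only, known or untested is meant among the compounds shown, and "the series" means these compounds.

Working notes on the series. The shared core of compound 1 `CSc1ccc(C2=C(c3ccc(C)c(C)c3)C(=O)N3CCCC3C2)cc1` carries a 4-(methylsulfanyl)phenyl group and a 3,4-dimethylphenyl group on the two double-bonded ring carbons. In a functional assay on A498 cells (Homo sapiens) for cytotoxicity (on this read-out lower numbers stand for stronger inhibition of growth and higher numbers for weaker inhibition of growth), compound 1 gives 300 nM. Compound 2 `CSc1ccc(C2=C(c3ccc(OCC4CO4)cc3)C(=O)N3CCCC3C2)cc1` replaces the 3,4-dimethylphenyl group with a 4-(2-oxiranylmethoxy)phenyl group, and in this assay compound 2 gives 500 nM. Compound 1 has the smaller of the two numbers, but the gap to compound 2 lies within the usual scatter, so the two cannot be told apart on these data.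

Compound 3 `CSc1ccc(C2=C(c3ccc(SC)cc3)C(=O)N3CCCC3C2)cc1` is not yet measured. It differs from compound 1 in one place: 4-(methylsulfanyl)phenyl in place of 3,4-dimethylphenyl on a double-bonded ring carbon. Among the compounds with values here, no step between measured compounds bears on this change, so no direction can be read from the series. Since both aryl groups on the core now match, the expectation for this assay is a step of a 1.2-fold higher number from compound 1 to compound 3 (0.07 log units; within the scatter), nothing beyond the scatter. Compound 3 is estimated at 350 nM, with a range from 150 nM to 800 nM.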

Compound 3, concentration for 50% growth inhibition: 15000 nM
Estimate against measurement, compound 3: 43-fold (1.63 log units) below; measured number outside the range, above it.
By their numbers in this assay, from the lowest: compounds 1 and 2 (each within the scatter of the next); then compound 3.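

The position on the double-bonded ring carbon is not indifferent to the aryl group it carries: in this assay, 4-(methylsulfanyl)phenyl in place of 3,4-dimethylphenyl gives a 50-fold higher number from compound 1 to compound 3 (1.70 log units; beyond the scatter), although both groups have the same heavy-atom count. Methylsulfanyl in place of (oxiran-2-yl)methoxy on an aromatic carbon gives a 30-fold higher number from compound 2 to compound 3 (1.48 log units; beyond the scatter), so two aryl groups that could not be told apart both stand well clear of the 4-(methylsulfanyl)phenyl group here. Nothing available explains this loss.

Going by these compounds, whether the sulfur atom matters remains open, and a methoxy, an amine or a carboxylic acid in place of methylsulfanyl on that aromatic carbon would test this. Also open, on these data alone, is whether the step holds when a different group replaces the 4-(methylsulfanyl)phenyl group on the ring atom that bears it.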